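The compounds below may be only part of what the source reports. "The series", "measured", "known", "first", "only" and "open" are said of these compounds alone.

Measured compounds in a functional assay on MGC-803 cells (Homo sapiens) for inhibition, read by MTT assay, with a stated time of 72 h; on this read-out higher numbers stand for weaker inhibition and lower numbers for stronger inhibition:

Compound 1, `Cc1ccc(-n2cc(CNC(=O)c3cccc4c3cnn4C(C)C)nn2)c(C)c1`: compound 1 gives > 40000 nM, which is a limit of this assay and not a number.
Compound 2, `CC(C)n1ncc2c(C(=O)NCc3cn(-c4ccc(C(F)(F)F)cc4)nn3)cccc21`: compound 2 gives > 40000 nM, also a limit of this assay rather than a number.
Compound 3, `CC(C)n1ncc2c(C(=O)NCc3cn(Cc4ccccc4)nn3)cccc21`: compound 3 gives 14300 nM.

Within the data shown here, compound 3 thus holds the only number in this assay; the other two values sit at the limit of > 40000 nM in this assay, at which 2 of the 3 values shown sit. The step of an at least 2.7-fold lower number from compound 1 to compound 3 (0.44 log units; beyond the scatter) and the step of an at least 2.7-fold lower number from compound 2 to compound 3 (0.44 log units; beyond the scatter) are both at least modest moves toward stronger inhibition, while a step that the two limits leave unreadable from compound 1 to compound 2 cannot be read from two limits.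

Compound 4, `CC(C)n1ncc2c(C(=O)NCc3cn(Cc4ccc(C(C)(C)C)cc4)nn3)cccc21`, differs from compound 3 by tert-butyl in place of hydrogen on an aromatic carbon. Among the measured compounds shown here, none of the measured steps touches a substituent on the benzyl ring itself; the measured steps only separate benzyl from directly attached aryl rings, so they give no direction for this change. For the step from compound 3 to compound 4 in this assay no move beyond the usual scatter is expected, a 1.2-fold lower number from compound 3 to compound 4 (0.08 log units; within the scatter). Compound 4 is therefore estimated at 12000 nM, with a range from 3000 nM to 40000 nM, and a real chance that this assay returns only a limit.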

Compound 4, half-maximal inhibitory concentration: > 40000 nM
Compound 4: no number, only a limit; the forecaster's own chance of this, stated with the estimate: 30%; middle value at least 3.3-fold (0.52 log units) from the limit.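

In this assay, among these compounds, compound 3 is the first compound to carry a change on the benzyl ring itself, and the tert-butyl group gives an at least 2.7-fold higher number from compound 3 to compound 4 (0.44 log units; beyond the scatter). Compound 4 gives > 40000 nM, which is a limit and not a number, so this step toward weaker inhibition has a minimum size but no known full size. A benzyl group alone therefore does not keep a compound of this series off the limit, and compound 3 still holds the only number: the limit of > 40000 nM in this assay, at which 3 of the 4 values shown sit.

Going by these compounds, whether the change follows from tert-butyl specifically or would appear with any group at this place remains open, and a methyl group or a fluorine atom there would help to separate the two. On these data alone, how an amine on the benzyl ring, or a longer chain in place of the benzyl group, would read in this assay is also open.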